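Amide to Butylamino on a Shared Triazolopyrimidine Amine

The source may hold more compounds than are shown below. What is called first, only, known or untested is meant among the compounds shown, and "the series" means these compounds.

Measured compounds:
compound 1 `COc1ccc(C(=O)Nc2nc(-c3ccccc3)nc3c2nnn3Cc2ccccc2F)cc1` — 21900000 nM
compound 2 `Clc1ccccc1Cn1nnc2c(NC3CCCC3)nc(-c3ccccc3)nc21` — 9000000 nM

Of the compounds shown here, two have been tested in an assay on isolated protein for binding affinity to adenosine receptor A1 (Bos taurus); a lower number here means a stronger inhibitor, a higher number a weaker inhibitor. Compound 1 gives 21900000 nM, the highest of the two numbers. Compound 2, which carries a cyclopentylamino group in place of the amide and a different halogen on its benzyl group, gives 9000000 nM; the gap between the two lies beyond the usual scatter, so compound 2 is the stronger inhibitor of the pair. Compound 2 differs from compound 1 in more than one place. No single step can be read from them.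

Compound 3 `CCCCNc1nc(-c2ccccc2)nc2c1nnn2Cc1ccccc1F` has not yet been measured in this assay. It differs from compound 1 in one place: butyl in place of (4-methoxyphenyl)carbonyl on a nitrogen on an aromatic ring. Compound 2 shows that a simple amino substituent on this nitrogen goes with a lower number than the amide of compound 1, so a move in the same direction is expected here, of moderate size. Compound 3 is therefore expected to give about 8000000 nM, within a range of 2500000 nM to 25000000 nM, which corresponds to an expected step of a 2.7-fold lower number from compound 1 to compound 3 (0.44 log units; beyond the scatter).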

Compound 3, inhibition constant: 4300000 nM
Compound 3: middle estimate off by 1.9-fold (0.27 log units), on the high side, and the stated range covers the measured number.
By their numbers in this assay, from the lowest: compound 3; then compound 2; then compound 1.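

In this assay, among these compounds, the step from the amide to the butylamino group, a 5.1-fold lower number from compound 1 to compound 3 (0.71 log units; beyond the scatter), is the first comparison in which the change in number can be tied to the substituent on this nitrogen alone, with the rest of compound 1 kept in place. It shows that the (4-methoxyphenyl)carbonyl group is not needed for the lower number here, since butyl, which has no ring and no hydrogen-bond acceptor, goes with a number beyond the scatter on the favourable side. No measurement shown here accounts for this step, so it stands as an observation without an explanation.

The exchange removes the carbonyl and the aromatic ring together and adds a flexible chain, so the compounds shown cannot tell which of these parts of the change carries the step; a benzylamino group, which keeps the ring without the carbonyl, or a pentanoyl amide, which keeps the carbonyl without the ring, would pull them apart. Also open, as far as these compounds go, is how the number responds to chain length on this nitrogen, as with a propyl or hexyl chain, or to a cyclopentylamino group on the same fluorinated benzyl core.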